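The source may hold more compounds than are shown below. What is called first, only, known or untested is meant among the compounds shown, and "the series" means these compounds.

Measured compounds:
- compound 1, `C[C@H](Nc1nc(N)nc(N)c1C#N)c1cc(=O)n2cc(F)ccc2c1-c1ccc(F)cc1`, "not determined" (no result reported)
- compound 2, `Cc1c([C@H](C)Nc2ncnc(N)c2C#N)c(-c2ccc(F)cc2)c2ccc(F)cn2c1=O`, "not determined" (no result reported)
- compound 3, `C[C@H](Nc1ncnc(N)c1C#N)c1c(C2CC2)c(=O)n2cc(F)ccc2c1-c1ccc(F)cc1`, 1%

Three compounds from this series were entered into an ADME assay on microsomes from liver (Rattus norvegicus), read by LC-MS, using NADPH, with a stated time of 30 min, tested at 1 uM (a lower number here means that less of the compound is left, a higher number that more of the compound is left), but only one of them returned a number. In this assay compound 1 is recorded as "not determined" (no result reported), and in this assay compound 2 is recorded as "not determined" (no result reported). Compound 3 therefore stands alone: in this assay compound 3 gives 1%, which is the lowest reading a compound of this set has shown, and also the only one, so nothing can be said about how its neighbours compare to it.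

The next compound in line is compound 4, `C[C@H](Nc1nc(N)nc(N)c1C#N)c1c(C2CC2)c(=O)n2cc(F)ccc2c1-c1ccc(F)cc1`. It differs from compound 3 in one place: amino in place of hydrogen on an aromatic carbon. For the measured compounds named here, no pair of measured compounds in this set shares that change, so there is no measured step to lean on for its size or direction.

Going by the values given here, with compound 3 already close to the bottom of the scale, a further fall is hardly possible, and the single number gives no ground for expecting a large rise either. Compound 4 is expected to stay near compound 3, with an estimated step of a number 4 percentage points higher from compound 3 to compound 4 (within the scatter). For compound 4 in this assay the estimate is 5%, within a range from 0% to 25%.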

Compound 4, percent of the compound remaining: 35%
For compound 4 the middle estimate is 30 percentage points below the measured one; the measured number lies above the stated range.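

For the compounds shown here, the step of a number 34 percentage points higher from compound 3 to compound 4 (beyond the scatter) is the only measured step in this set, and it shows that the aromatic carbon between two ring nitrogen atoms is a position where a single change can move the reading in this assay beyond the scatter. Compound 3 alone could not show whether the percent remaining responds to any change in this series, whereas the move from 6-amino-5-cyanopyrimidin-4-yl to 2,6-diamino-5-cyanopyrimidin-4-yl, with the rest of the structure held the same, shows that it does. Nothing measured here accounts for the rise, so its origin remains unexplained.

Going by these compounds, it remains open whether the rise is particular to the amino group or would also appear with another small group at this position, such as a methyl group, a methoxy group or a fluorine atom. Also open, on these data alone, is whether a longer chain on that nitrogen, such as a methylamino or ethylamino group, would keep, extend or lose the step seen in this assay for this change.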